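Replacing the pyrrolyl group of compound 3 with acetoxy

The source may report more compounds than this note shows. Statements on the series, on what has been measured and on what is new or still open speak of the compounds shown alone.

Of the compounds shown here, three on a shared core have been measured in a functional assay (trachea) with Rattus norvegicus as the target; a higher number here means a more potent compound, by a factor of ten per unit of this negative logarithm, a lower number a less potent compound. Compound 1 `CC1(C)C=C(n2ccccc2=O)c2cc(C(=O)c3ccc(O)cc3)ccc2O1` gives 5.87, compound 2 `CC1(C)C=C(n2ccccc2=O)c2cc(C(=O)c3ccccc3F)ccc2O1` gives 6.34, and compound 3 `Cc1ccc(C)n1-c1ccc2c(c1)C(n1ccccc1=O)=CC(C)(C)O2` gives 6.78. Compound 3 therefore stands highest of the three, with the step of a number 0.44 log units higher from compound 2 to compound 3 (beyond the scatter) and the step of a number 0.91 log units higher from compound 1 to compound 3 (beyond the scatter), both beyond the scatter, and the step of a number 0.47 log units higher from compound 1 to compound 2 (beyond the scatter) separating the other two.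

Compound 4 `CC(=O)Oc1ccc2c(c1)C(n1ccccc1=O)=CC(C)(C)O2` is built from compound 3 by the change (acetoxy in place of 2,5-dimethyl-1H-pyrrol-1-yl on an aromatic carbon). Both steps leading to compound 3 bear on this: replacing an aryl carbonyl group at this aromatic carbon with the 2,5-dimethyl-1H-pyrrol-1-yl group raised potency in this assay by modest amounts. Within the data shown here, removing that group again is expected to give back part of that gain, although no measured compound carries acetoxy, so its own effect is unknown. Compound 4 is thus expected to show a modest downward step, a number 0.88 log units lower from compound 3 to compound 4 (beyond the scatter), in this assay. The estimate for compound 4 is 5.9, with a range from 5.2 to 6.6.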

Compound 4, logarithm of the reciprocal of the active concentration, log(1/C): 4.97
Estimate against measurement, compound 4: 0.93 log units above, outside the stated range (below it).
By their numbers in this assay, from the lowest: compound 4; then compound 1; then compound 2; then compound 3.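

In this assay, among these compounds, the change from 2,5-dimethyl-1H-pyrrol-1-yl to acetoxy on this aromatic carbon gives a number 1.81 log units lower from compound 3 to compound 4 (beyond the scatter) and is a large step, wider than any step among the earlier compounds at this position. Acetoxy also stands below both aryl carbonyl groups, with a number 1.37 log units lower from compound 2 to compound 4 (beyond the scatter) and with a number 0.90 log units lower from compound 1 to compound 4 (beyond the scatter) as well, so all three earlier groups at this carbon give higher numbers than acetoxy does. The data at hand offer no account of why acetoxy lies so low. On these data alone, whether a free hydroxyl, an amine or a carboxylic acid on this carbon would lie nearer compound 4 or nearer compound 3 remains open. So does whether an acetyl group joined through carbon rather than through oxygen would give a number like that of compound 4.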